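Amine Swap at the Propoxy Chain Terminus

This account rests on a few compounds, and the source may have more. Where it says the series, first, only, none or still open, it means among the compounds named here.

Compound 1 `CCN(CC)CCCOc1c(OCc2ccccc2)cc(O)c2c(=O)cc(-c3ccccc3)oc12`: 3010 nM
Compound 2 `O=c1cc(-c2ccccc2)oc2c(OCCCN3CCCC3)c(OCc3ccccc3)cc(O)c12`: 2660 nM

Among the compounds with values here, in a functional assay on HepG2 cells (Homo sapiens) for cytotoxicity, read by MTT assay, with a stated time of 72 h (on this read-out higher numbers stand for weaker inhibition and lower numbers for stronger inhibition), compound 2 stands at the lower of the two numbers measured so far, but its step from compound 1 is small: a 1.1-fold lower number from compound 1 to compound 2 (0.05 log units; within the scatter). Compound 3 `CN1CCN(CCCOc2c(OCc3ccccc3)cc(O)c3c(=O)cc(-c4ccccc4)oc23)CC1` has not yet been tested; it differs from compound 2 in that (4-methylpiperazin-1-yl in place of pyrrolidin-1-yl on a saturated chain carbon, three bonds along the chain from an oxygen on an aromatic ring). Within the data shown here, the only step that bears on it, the change of the terminal amine from compound 1 to compound 2, stayed within the scatter, so no step beyond the scatter is expected in this assay for compound 3, a 1.2-fold higher number from compound 2 to compound 3 (0.08 log units; within the scatter). For compound 3 a value around 3200 nM is estimated, between 1500 nM and 7000 nM.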

Compound 3, half-maximal inhibitory concentration: 3110 nM
Compound 3: middle estimate off by 1.0-fold (0.01 log units), on the high side; the measured number falls inside the stated range.
By their numbers in this assay, from the lowest: compounds 2, 1 and 3 (each within the scatter of the next).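

In this assay, a six-membered ring with a second nitrogen at the chain end changes little against the pyrrolidine, a 1.2-fold higher number from compound 2 to compound 3 (0.07 log units; within the scatter), or against the open-chain diethylamino group, a 1.0-fold higher number from compound 1 to compound 3 (0.01 log units; within the scatter). All three amines thus lie within the scatter of one another, so this position has so far shown no sensitivity to which of these amines it carries. Nothing available bears on why these numbers stay so close. Going by these compounds, whether a morpholine, a primary amine or a carboxylic acid at the chain end would behave alike remains open, as does the effect of a shorter or longer chain.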